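Side chain on sulfur: compound 3 to compound 4

The source may report more compounds than this note shows. Statements on the series, on what has been measured and on what is new or still open speak of the compounds shown alone.

In an ADME assay on MT4 cells (Homo sapiens) for cytotoxicity, read by MTT assay (on this read-out higher numbers stand for lower toxicity in this test and lower numbers for higher toxicity in this test), compound 1 `O=c1cc(Cc2c(F)cccc2F)nc(SCc2c(F)cccc2F)[nH]1` gives > 66000 nM, which is a limit and not a number. Compound 2 `O=c1cc(Cc2c(F)cccc2F)nc(SCCc2ccccc2)[nH]1` gives > 70000 nM, again only a limit. Within the data shown here, compound 3 `O=c1cc(Cc2c(F)cccc2F)nc(SCCCc2ccccc2)[nH]1` gives 32000 nM, the only true number among the three and the lowest reading of the series. The readings show an at least 2.0-fold lower number from compound 1 to compound 3 (0.31 log units; beyond the scatter) and an at least 2.1-fold lower number from compound 2 to compound 3 (0.33 log units; beyond the scatter). The two limits leave a step that the two limits leave unreadable from compound 1 to compound 2.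

Compound 4 `O=C(CSc1nc(Cc2c(F)cccc2F)cc(=O)[nH]1)c1ccccc1`, still unmeasured, carries benzoyl in place of phenethyl on a saturated chain carbon bound to a sulfur. All three measured steps vary the group at this sulfur, but none of them introduces a carbonyl, so they bear on the change only indirectly. Compound 3 sits apart from compound 2 by an at least 2.1-fold lower number from compound 2 to compound 3 (0.33 log units; beyond the scatter), and a departure from the side chain of compound 3 is therefore expected to lean back towards the higher numbers. In this assay the expected change is small and upward, possibly no larger than the scatter, and is written as a 1.6-fold higher number from compound 3 to compound 4 (0.19 log units; within the scatter). A reading that is only a limit is also quite possible. The estimate for compound 4 is 50000 nM, with an expected range from 20000 nM to 110000 nM.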

Compound 4, half-maximal cytotoxic concentration: > 67000 nM
Compound 4 was reported as a limit; the forecaster's own chance of this, stated with the estimate: 45%; middle value at least 1.3-fold (0.12 log units) away from the limit.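

In this assay compound 4 is reported as a limit and not a number: the limit of > 67000 nM in this assay, at which 1 of the 4 values shown sits. Benzoyl in place of phenethyl on a saturated chain carbon bound to a sulfur gives an at least 2.0-fold higher number from compound 3 to compound 4 (0.32 log units; beyond the scatter), the first readable step at this position that brings in a carbonyl, and it runs towards lower toxicity in this test. Compound 3 is now the only one of the four with a true number, while compound 1, compound 2 and compound 4 are all limits, so the steps from compound 1 and from compound 2 to compound 4 cannot be read.

How far the true readings of compound 1, compound 2 and compound 4 lie past their limits stays open, so no order among these three can be given. Also open, as far as these compounds go, is whether the higher reading follows the carbonyl itself or simply any departure from the side chain of compound 3, and a hydroxyl in place of the carbonyl, or an amine on the same chain, would be the next groups to read in this assay.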